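A few compounds are considered here, and "the series" means these few. Any claim that something is new, unique, unknown or untested is made for them only; others in the source may bear on it.

Compound 1 (`COc1ccc(/C=C2\CN(Cc3cn(Cc4cccc(Cl)c4)nn3)C/C(=C\c3ccc(OC)cc3)C2=O)cc1`): 56600 nM 
Compound 2 (`COc1ccc(/C=C2\CN(Cc3cn(Cc4ccc(F)cc4)nn3)C/C(=C\c3ccc(OC)cc3)C2=O)cc1`): 49300 nM 

Among the measured compounds shown here, in a functional assay on 4T1 cells (Mus musculus) for cytotoxicity, read by MTT assay, with a stated time of 24 h (a higher number here means a weaker inhibitor, a lower number a stronger inhibitor), compound 2 gives 49300 nM and cannot be separated from compound 1, the only other measured compound. The change to compound 3 (`COc1ccc(/C=C2\CN(Cc3cn(Cc4ccccc4Cl)nn3)C/C(=C\c3ccc(OC)cc3)C2=O)cc1`) is 2-chlorophenyl in place of 4-fluorophenyl on a saturated chain carbon bound to an aromatic nitrogen. For the measured compounds named here, the one measured step at this place is a 1.1-fold lower number from compound 1 to compound 2 (0.06 log units; within the scatter) and it stayed within the scatter. Going by the values given here, no measured compound carries 2-chlorophenyl, so this is thin evidence, but no shift beyond the scatter is expected in this assay here. The expected step is a 1.0-fold higher number from compound 2 to compound 3 (0.01 log units; within the scatter) in size. For compound 3 the estimated value is 50000 nM with an expected range from 28000 nM to 90000 nM in this measurement.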

Compound 3, half-maximal inhibitory concentration: 11400 nM
Compound 3: the middle estimate sits 4.4-fold (0.64 log units) above what was measured; measured number below the stated range.
By their numbers in this assay, from the lowest: compound 3; then compounds 2 and 1 (each within the scatter of the next).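

In this assay, the group at this place, on a saturated chain carbon bound to an aromatic nitrogen, now shows a real effect: 2-chlorophenyl gives a 4.3-fold lower number from compound 2 to compound 3 (0.64 log units; beyond the scatter) and a 5.0-fold lower number from compound 1 to compound 3 (0.70 log units; beyond the scatter). Since 3-chlorophenyl and 2-chlorophenyl carry the same atoms, where the chlorine sits on the ring matters, not merely its presence. Nothing at hand explains the shift.

Going by these compounds, whether 2-fluorophenyl or 2-methylphenyl would match 2-chlorophenyl remains open. So does how plain phenyl or 4-chlorophenyl would compare.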